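Swapping the chain amine on the strongest of three thienyl amides

This account rests on a few compounds, and the source may have more. Where it says the series, first, only, none or still open, it means among the compounds named here.

Of the compounds shown here, three sharing one core have been measured in a functional assay on K562 cells (Homo sapiens) for inhibition, read by MTT assay and WST assay, with a stated time of 72 h, tested at 10 uM; on this read-out lower numbers stand for less inhibition of growth and higher numbers for more inhibition of growth at the one concentration tested. Compound 1 `Cc1nc(Nc2ccc3sc(C(=O)Nc4c(C)cccc4Cl)cc3c2)cc(N2CCCCC2)n1` gives 8.78% in this assay. Within the data shown here, compound 3 `Cc1nc(Nc2ccc3sc(C(=O)Nc4c(C)cccc4Cl)cc3c2)cc(N2CCN(C)CC2)n1` gives 32.4% in this assay, and the single measured step, a number 23.6 percentage points higher from compound 1 to compound 3 (beyond the scatter), is the only one that touches a change of amine ring. Compound 2 `COc1cc2c(Nc3ccc4sc(C(=O)Nc5c(C)cccc5Cl)cc4c3)ncnc2cc1OCCCN1CCCCC1C` gives 84.2% in this assay and stands highest of the three numbers, beyond the scatter above both compound 3 and compound 1.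

The unmeasured compound 4 `COc1cc2c(Nc3ccc4sc(C(=O)Nc5c(C)cccc5Cl)cc4c3)ncnc2cc1OCCCN1CCN(C)CC1` differs from compound 2 by 4-methylpiperazin-1-yl in place of 2-methylpiperidin-1-yl on a saturated chain carbon, three bonds along the chain from an oxygen on an aromatic ring. The step from compound 1 to compound 3 bears on this only loosely: there the amine ring sat on an aromatic carbon and the leaving ring carried no methyl, whereas in compound 4 the exchange is made on a saturated chain carbon, three bonds along the chain from an oxygen on an aromatic ring. That earlier step was modest and upward, but compound 2 already sits near the top of the range of this assay, so little room remains. Compound 4 is therefore expected to give 86% in this assay, within 70% to 97%, a step of a number 1.8 percentage points higher from compound 2 to compound 4 (within the scatter) that is estimated not to exceed the scatter.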

Compound 4, percent growth inhibition at one concentration: 51.2%
Beside the measured number, compound 4's estimate is 34.8 percentage points above it; measured number below the stated range.
By their numbers in this assay, from the lowest: compound 1; then compound 3; then compound 4; then compound 2.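

In this assay, the amine on a saturated chain carbon, three bonds along the chain from an oxygen on an aromatic ring, proves to matter: exchanging 2-methylpiperidin-1-yl for 4-methylpiperazin-1-yl gives a number 33 percentage points lower from compound 2 to compound 4 (beyond the scatter) even though both groups are six-membered non-aromatic rings. The same entering group went with a change in the opposite direction in the earlier pair, a number 23.6 percentage points higher from compound 1 to compound 3 (beyond the scatter) where the ring sat on an aromatic carbon and the leaving group was piperidin-1-yl, so across these two pairs 4-methylpiperazin-1-yl has no single direction of effect. Nothing available here accounts for the size of the new step or for the difference in direction between the two pairs.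

The compounds shown leave open whether the drop follows the second ring nitrogen or the different place of the methyl, a question that 3-(piperidin-1-yl)propyl and 3-(4-methylpiperidin-1-yl)propyl chains would help to separate. They also leave open how a morpholin-4-yl ring or a dimethylamino group would read at this place, and whether a 2-(2-methylpiperidin-1-yl)ethyl chain would hold the high number of the parent compound.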